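A few compounds are considered here, and "the series" means these few. Any claim that something is new, unique, unknown or untested is made for them only; others in the source may bear on it.

Of the compounds shown here, three that share one core have been measured in a functional assay on DU-145 cells (Homo sapiens) for cytotoxicity, read by sulforhodamine B assay, with a stated time of 48 h (a higher number here means a weaker inhibitor, a lower number a stronger inhibitor), and they differ in the aromatic group on the carbon with a double bond to nitrogen. Compound 1 `C[C@H]1CC[C@@H]2[C@@H](OC(=O)[C@]23CC(c2ccc(N(C)C)cc2)=NO3)[C@]2(C)C(=O)C=C[C@@]12O`, with a 4-(dimethylamino)phenyl group, gives 4500 nM. Compound 2 `C[C@H]1CC[C@@H]2[C@@H](OC(=O)[C@]23CC(c2ccccc2[N+](=O)[O-])=NO3)[C@]2(C)C(=O)C=C[C@@]12O`, with a 2-nitrophenyl group, gives 34000 nM, and compound 3 `COc1cc(C2=NO[C@]3(C2)C(=O)O[C@@H]2[C@H]3CC[C@H](C)[C@]3(O)C=CC(=O)[C@@]23C)ccc1O`, with a 4-hydroxy-3-methoxyphenyl group, gives 71000 nM. That makes compound 2 the second highest of the three numbers.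

Compound 4 `C[C@H]1CC[C@@H]2[C@@H](OC(=O)[C@]23CC(c2ccccc2Cl)=NO3)[C@]2(C)C(=O)C=C[C@@]12O` is compound 2 with one change: chloro in place of nitro on an aromatic carbon. In words, this is chloro in place of nitro on an aromatic carbon, or 2-nitrophenyl to 2-chlorophenyl.

Among the compounds with values here, no measured compound carries chloro, so no measured step tests this swap directly. The closest evidence is what changing the aromatic group has done so far, with steps ranging from modest to large: a 2.1-fold higher number from compound 2 to compound 3 (0.32 log units; beyond the scatter), a 7.6-fold higher number from compound 1 to compound 2 (0.88 log units; beyond the scatter) and a 16-fold higher number from compound 1 to compound 3 (1.20 log units; beyond the scatter). Those steps give no direction for this swap, so no step beyond the scatter is expected in this assay, although their size argues for a wide range. The expected change is a 1.4-fold lower number from compound 2 to compound 4 (0.13 log units; within the scatter). For compound 4 the estimated value is 25000 nM, with an expected range from 7000 nM to 70000 nM.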

Compound 4, half-maximal inhibitory concentration: 19000 nM
The estimate for compound 4 lay 1.3-fold (0.12 log units) above the measured number, within the range that was stated.
By their numbers in this assay, from the lowest: compound 1; then compounds 4 and 2 (each within the scatter of the next); then compound 3.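

In this assay, nitro and chloro on the same aromatic carbon give a 1.8-fold lower number from compound 2 to compound 4 (0.25 log units; within the scatter), so this swap cannot be told apart from the scatter, even though chloro has 1 heavy atom where nitro has 3. The 2-chlorophenyl group still differs clearly from the two other aromatic groups, with a 3.7-fold lower number from compound 3 to compound 4 (0.57 log units; beyond the scatter) and a 4.2-fold higher number from compound 1 to compound 4 (0.63 log units; beyond the scatter), which leaves compound 1 the strongest of the four and compound 3 the weakest, with compound 2 and compound 4 together in the middle. No measurement here explains why these aromatic groups give different numbers.

The compounds shown leave open whether the lower number of compound 1 depends on the dimethylamino group itself or on where that group sits, since each aromatic group differs from the others in both its substituents and their places on the ring. They also leave open how an unsubstituted phenyl group, a primary amine or a carboxylic acid on this ring would read in this assay, and so how far this position can be pushed below the number of compound 1.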